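The compounds below may be only part of what the source reports. "The series", "measured", "known", "first", "only" and "open" are said of these compounds alone.

Compound 1, with structure `CCC[C@@H]1NC(=O)[C@@H](C(C)C)NC(=O)[C@@H](Cc2ccc(O)cc2)NCCOc2ccccc2CCCNC1=O`, is the reference point of this small set. In an assay on isolated protein for displacement of a labelled ligand from Motilin receptor (Homo sapiens) (a lower number here means a stronger inhibitor, a higher number a weaker inhibitor), compound 1 gives 55 nM, the lowest of the three numbers recorded. Compound 2, `CCC[C@@H]1NC(=O)[C@@H](C(C)C)NC(=O)[C@@H](CCc2ccccc2)NCCOc2ccccc2CCCNC1=O`, gives 1490 nM in this assay, and compound 3, `CCC[C@@H]1NC(=O)[C@@H](C(C)C)NC(=O)[C@@H](Cc2c[nH]c3ccccc23)NCCOc2ccccc2CCCNC1=O`, gives 255 nM. Both comparisons place compound 1 ahead: the step of a 27-fold higher number from compound 1 to compound 2 (1.43 log units; beyond the scatter) is large, and the step of a 4.6-fold higher number from compound 1 to compound 3 (0.67 log units; beyond the scatter) is modest, as is the step of a 5.8-fold lower number from compound 2 to compound 3 (0.77 log units; beyond the scatter).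

Compound 4, `CCC[C@@H]1NC(=O)[C@@H](C(C)C)N(C)C(=O)[C@@H](Cc2ccc(O)cc2)NCCOc2ccccc2CCCNC1=O`, is not yet measured. It differs from compound 1 by methyl in place of hydrogen on an amide-type nitrogen in a ring. Among the measured compounds shown here, none of the measured steps bears directly on this change: each of them alters the side group on a saturated chain carbon, while the ring nitrogens of the shared core are untouched throughout. There is therefore no measured basis for the direction or size of the step, and compound 4 is estimated at 110 nM in this assay, within a wide range from 15 nM to 800 nM, which corresponds to an expected step of a 2.0-fold higher number from compound 1 to compound 4 (0.30 log units; within the scatter).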

Compound 4, inhibition constant: > 10000 nM
Compound 4: no number, only a limit; the forecaster's own chance of this, stated with the estimate: 5%; middle value at least 90-fold (1.95 log units) from the limit.
By their numbers in this assay, from the lowest: compound 1; then compound 3; then compound 2. At a limit, above all of these: compound 4.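

Methyl in place of hydrogen on the amide-type nitrogen in the ring, next to the ring atom that bears an isopropyl group, is the only change shown that touches the shared core rather than a side group. In this assay this single added heavy atom gives an at least 180-fold higher number from compound 1 to compound 4 (2.25 log units; beyond the scatter), a larger step than the largest side-group step, a 27-fold higher number from compound 1 to compound 2 (1.43 log units; beyond the scatter), so this position tolerates far less change than the side group does. The reading for compound 4 is a limit and not a number: the limit of > 10000 nM in this assay, at which 1 of the 4 values shown sits.

The compounds shown leave open whether an ethyl or a longer chain on this nitrogen would read the same way. They also leave open whether methyl on the other amide-type nitrogens of the ring would give a step of similar size.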